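The source may report more compounds than this note shows. Statements on the series, on what has been measured and on what is new or still open speak of the compounds shown alone.

Compound 1 `O=C1NC(=O)/C(=C\c2ccc(OCC(=O)N3N=C(c4ccc(F)cc4)CC3c3ccccc3)cc2)S1`: 4200 nM
Compound 2 `O=C1NC(=O)/C(=C\c2ccc(OCC(=O)N3N=C(c4ccc(F)cc4)CC3c3ccco3)cc2)S1`: 880 nM

Both numbers come from an assay on cells for inhibition of histone deacetylase 4 (Homo sapiens), read by fluorescence, with a stated time of 30 min; on this read-out lower numbers stand for stronger inhibition and higher numbers for weaker inhibition. Compound 2 stands at the lower of the two values; compound 1 gives the higher one, and the distance between them is a 4.8-fold lower number from compound 1 to compound 2 (0.68 log units; beyond the scatter), a difference beyond the usual scatter. Compound 3 `O=C1NC(=O)/C(=C\c2ccc(OCC(=O)N3N=C(c4ccc(F)cc4)CC3c3ccc(C(F)(F)F)cc3)cc2)S1` has not yet been measured. It differs from compound 2 in one place: 4-(trifluoromethyl)phenyl in place of furan-2-yl on a saturated ring carbon. Among the compounds with values here, only one measured step bears on this change, a 4.8-fold lower number from compound 1 to compound 2 (0.68 log units; beyond the scatter), which shows that a furan-2-yl ring on that saturated ring carbon gave a lower number than a phenyl ring there. Within the data shown here, compound 3 returns a six-membered carbon-only ring to the same saturated ring carbon, now carrying a trifluoromethyl group, and no measured step shows what that group does. The expected step is therefore a rise of about a 3.4-fold higher number from compound 2 to compound 3 (0.53 log units; beyond the scatter). Compound 3 is estimated at 3000 nM, with a likely range from 800 nM to 12000 nM.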

Compound 3, half-maximal inhibitory concentration: 1300 nM
Compound 3: the middle estimate sits 2.3-fold (0.36 log units) above what was measured; measured number inside the range.
By their numbers in this assay, from the lowest: compounds 2 and 3 (each within the scatter of the next); then compound 1.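

In this assay the step of a 1.5-fold higher number from compound 2 to compound 3 (0.17 log units; within the scatter) shows that a furan-2-yl ring is not needed on this saturated ring carbon: the much larger 4-(trifluoromethyl)phenyl, with no hydrogen-bond acceptor, cannot be told apart from it here. The step of a 3.2-fold lower number from compound 1 to compound 3 (0.51 log units; beyond the scatter) adds that a six-membered carbon-only ring at this place need not stay at the higher number of compound 1, since trifluoromethyl in place of hydrogen on that ring is enough to move it beyond the scatter. Nothing measured here explains either step.

On these data alone, whether the effect belongs to trifluoromethyl in particular stays open, since an amine or a carboxylic acid on the same phenyl ring might move the number differently. As far as these compounds go, how a group on the furan ring would behave also remains unknown.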